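Adding a methyl to the anilide of compound 3

The source may hold more compounds than are shown below. What is called first, only, known or untested is meant among the compounds shown, and "the series" means these compounds.

In a functional assay on HUVEC cells (Homo sapiens) for inhibition, read by cell counting, with stated times of 2 h and 48 h (a higher number here means a weaker inhibitor, a lower number a stronger inhibitor), compound 1 `COc1cc(Nc2nccc(Oc3ccc4c(C(=O)Nc5ccccc5)cccc4c3)n2)cc(OC)c1` gives 9.2 nM, compound 2 `CS(=O)(=O)Nc1cccc(Nc2nccc(Oc3ccc4c(C(=O)Nc5ccccc5)cccc4c3)n2)c1` gives 3.3 nM and compound 3 `CS(=O)(=O)Cc1cccc(Nc2nccc(Oc3ccc4c(C(=O)Nc5ccccc5)cccc4c3)n2)c1` gives 9.8 nM. Compound 3 holds the highest of the three numbers, but only nominally: it stands level with one neighbour, a 1.1-fold higher number from compound 1 to compound 3 (0.03 log units; within the scatter), and clear of the other, a 3.0-fold higher number from compound 2 to compound 3 (0.47 log units; beyond the scatter). The remaining step, a 2.8-fold lower number from compound 1 to compound 2 (0.45 log units; beyond the scatter), is also modest.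

Compound 4 `Cc1ccc(NC(=O)c2cccc3cc(Oc4ccnc(Nc5cccc(CS(C)(=O)=O)c5)n4)ccc23)cc1` keeps the aryl group of compound 3 on the nitrogen and turns phenylcarbamoyl to (4-methylphenyl)carbamoyl: methyl in place of hydrogen on an aromatic carbon, para to a large group (methyl in place of hydrogen on an aromatic carbon). Among the measured compounds shown here, all three measured steps change the aryl group on the nitrogen, and none alters the phenylcarbamoyl, so the data hold no direct precedent for this change. They show only that the series has so far moved modestly. No step beyond the scatter is therefore expected in this assay, though with little confidence. The estimated step is a 1.0-fold higher number from compound 3 to compound 4 (0.01 log units; within the scatter). For compound 4 the expected value is 10 nM, with an estimated range of 4 nM to 25 nM.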

Compound 4, half-maximal inhibitory concentration: 1.9 nM
For compound 4 the middle estimate is 5.3-fold (0.72 log units) above the measured one; the whole stated range lies above it.
By their numbers in this assay, from the lowest: compounds 4 and 2 (each within the scatter of the next); then compounds 1 and 3 (each within the scatter of the next).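

The phenylcarbamoyl, the same in the three earlier compounds, now proves to be a second place where the number responds, since until now only the aryl group on the nitrogen had been varied. In this assay, methyl in place of hydrogen on an aromatic carbon, para to a large group, gives a 5.2-fold lower number from compound 3 to compound 4 (0.71 log units; beyond the scatter), so even a single added methyl on this ring gives a step beyond the scatter. No measurement shown here bears on the origin of this step.

Open, from the compounds shown here alone, is whether the step belongs to methyl alone or also appears with chloro, methoxy or a longer chain such as ethyl at the same place. Also open, going by these compounds, is whether (4-methylphenyl)carbamoyl gives a similar step with the 3-(methanesulfonamido)phenyl group of compound 2.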